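Replacing the acetylpiperazine amide with an ethylpiperidine amide

The source may report more compounds than this note shows. Statements on the series, on what has been measured and on what is new or still open speak of the compounds shown alone.

Measured compounds and their values in a functional assay on A2780 cells (Homo sapiens) for antiproliferative activity, read by fluorescence, with a stated time of 72 h; on this read-out lower numbers stand for stronger inhibition and higher numbers for weaker inhibition:
compound 1, `CN1CCC(C(=O)N2Cc3c(NC(=O)c4ccccc4)n[nH]c3C2(C)C)CC1`, gives 160 nM.
compound 2, `CC(=O)N1CCN(C(=O)N2Cc3c(NC(=O)c4ccc(F)cc4)n[nH]c3C2(C)C)CC1`, gives only a limit of the assay, > 10000 nM.
compound 3, `CN1CCC(C(=O)N2Cc3c(NC(=O)c4ccc(Cl)cc4)n[nH]c3C2(C)C)CC1`, gives 120 nM.

Among the measured compounds shown here, compound 2 stands apart from the other two measured compounds: its result in this assay is a limit of the assay and not a number, and it is the one value of the three that sits at the limit of > 10000 nM in this assay, at which 1 of the 3 values shown sits. For the measured compounds named here, compounds 1 and 3, which share a 1-methylpiperidin-4-yl group on the carbonyl carbon, both give numbers well inside the measured range; the one step between them, a 1.3-fold lower number from compound 1 to compound 3 (0.12 log units; within the scatter), lies within the scatter.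

Compound 4, `CCN1CCC(C(=O)N2Cc3c(NC(=O)c4ccc(F)cc4)n[nH]c3C2(C)C)CC1`, is reached from compound 2 by a change on the carbonyl carbon: 1-ethylpiperidin-4-yl in place of 4-acetylpiperazin-1-yl on a carbonyl carbon. Going by the values given here, no measured step covers this exchange directly. What the measured compounds show is that the piperidine amides in compounds 1 and 3 give numbers near each other, and that a change on the aromatic ring moved little. Compound 4 carries the same fluoro-substituted aryl amide as compound 2 but the piperidine amide of compounds 1 and 3, so a large drop in the number is expected, an at least 66-fold lower number from compound 2 to compound 4 (1.82 log units; beyond the scatter). Compound 4 is therefore estimated at 150 nM, with a range from 50 nM to 500 nM.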

Compound 4, half-maximal inhibitory concentration: 290 nM
Compound 4: middle estimate off by 1.9-fold (0.29 log units), on the low side, and the stated range covers the measured number.
By their numbers in this assay, from the lowest: compounds 3, 1 and 4 (each within the scatter of the next, the first and the last beyond it). At a limit, above all of these: compound 2.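

In this assay, among the compounds shown here, the exchange on the carbonyl carbon, whose other neighbour is an amide-type nitrogen in a ring, gives a large step, an at least 34-fold lower number from compound 2 to compound 4 (1.53 log units; beyond the scatter), with the fluoro-substituted aryl amide held the same, so this position can move the result far more than the one aromatic change seen so far. For the compounds shown here, compounds 1 and 3 differ only on the aromatic ring, and compound 2 differs from each of them in two places, so none of the earlier compounds gave a reading of this position alone. The result for compound 2 is a limit of the assay and not a number, so the step has no upper end: the limit of > 10000 nM in this assay, at which 1 of the 4 values shown sits.

The exchange alters the ring and the group it carries together, so the compounds shown do not separate the loss of the acetyl group from the change from 4-acetylpiperazin-1-yl to a piperidine. Still open, going by these compounds, is whether a 4-ethylpiperazin-1-yl or a 1-acetylpiperidin-4-yl group on the same carbonyl carbon would read nearer to compound 2 or to compound 4, and how a propyl chain in place of the ethyl would read.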